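Swapping a Furan for a Fluorinated Methoxyphenyl on Two Cores

A few compounds are considered here, and "the series" means these few. Any claim that something is new, unique, unknown or untested is made for them only; others in the source may bear on it.

Of the compounds shown here, three have so far been tested in an ADME assay for permeability, using PAMPA, with a stated time of 30 min, at pH 7.4; on this read-out lower numbers stand for lower permeability and higher numbers for higher permeability. Compound 1 `c1ccc(Cc2ccc3c(NCCCNCc4ccco4)ccnc3c2)cc1` gives 23 10^-6 cm/s in this assay, and compound 2 `COc1ccc(F)cc1CNCCCNc1ccnc2cc(Cc3ccccc3)ccc12` gives 23 10^-6 cm/s. These two differ only in one group, (5-fluoro-2-methoxyphenyl in place of furan-2-yl on a saturated chain carbon bound to an amine nitrogen), and that change gave no change at the digits printed from compound 1 to compound 2 (within the scatter). Compound 3 `COc1ccc(-c2ccc3c(NCCCNCc4ccco4)ccnc3c2)cc1` gives 237 10^-6 cm/s in this assay; its core differs from the core of compound 1 by 4-methoxyphenyl in place of benzyl on an aromatic carbon, a change that gave a 10-fold higher number from compound 1 to compound 3 (1.01 log units; beyond the scatter). Compound 4 `COc1ccc(-c2ccc3c(NCCCNCc4cc(F)ccc4OC)ccnc3c2)cc1` has the core of compound 3 and carries the same change already seen on the other core: 5-fluoro-2-methoxyphenyl in place of furan-2-yl on a saturated chain carbon bound to an amine nitrogen. Among the compounds described, this change appears twice in all, once measured and once not. Because the same change gave no change at the digits printed from compound 1 to compound 2 (within the scatter), compound 4 is expected to stay close to compound 3 in this assay, with a step of about a 1.0-fold lower number from compound 3 to compound 4 (0.01 log units; within the scatter). Compound 4 is therefore estimated at 230 10^-6 cm/s, most likely falling between 115 10^-6 cm/s and 460 10^-6 cm/s, an expectation that rests on a single earlier instance of the change.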

Compound 4, apparent permeability: 237 10^-6 cm/s
Compound 4: middle estimate off by 1.0-fold (0.01 log units), on the low side; the range from low to high includes it.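

In this assay, putting 5-fluoro-2-methoxyphenyl in place of furan-2-yl on the core of compound 3 gave no change at the digits printed from compound 3 to compound 4 (within the scatter), and this matches what the same swap did on the core of compound 1: the same change on two cores in this assay, no change at the digits printed (within the scatter) from compound 1 to compound 2 and no change at the digits printed (within the scatter) from compound 3 to compound 4, 1.0-fold (0.00 log units) apart, within the scatter of two such steps. The other change, 4-methoxyphenyl in place of benzyl on an aromatic carbon, also carried over, now with the 5-fluoro-2-methoxyphenyl group present, giving a 10-fold higher number from compound 2 to compound 4 (1.01 log units; beyond the scatter): the same change on two cores in this assay, a 10-fold higher number (1.01 log units; beyond the scatter) from compound 1 to compound 3 and a 10-fold higher number (1.01 log units; beyond the scatter) from compound 2 to compound 4, 1.0-fold (0.00 log units) apart, within the scatter of two such steps. In these compounds, each change therefore gave the same result whichever form the other part of the molecule took, but this rests on just one pair per core, so it shows no general rule and does not explain why the numbers behave this way.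

The compounds shown leave open whether a pyridin-3-yl or cyclohexyl group in place of furan-2-yl would also leave the number in this assay unchanged. They also leave open whether the two changes would still act independently on a core with a longer chain.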